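The source may report more compounds than this note shows. Statements on the series, on what has been measured and on what is new or still open speak of the compounds shown alone.

Of the compounds shown here, three that share a common core have so far been tested in a functional assay on MONO-MAC-6 cells (Homo sapiens) for inhibition; on this read-out lower numbers stand for stronger inhibition and higher numbers for weaker inhibition. Compound 1 `C[C@@H](NS(=O)(=O)N1CC=C(c2ccc(Cl)cc2)CC1)C(=O)NO` gives 1240 nM in this assay. Compound 2 `O=C(NO)[C@H]1CCCCN1S(=O)(=O)N1CC=C(c2ccc(F)cc2)CC1` gives 300 nM, and compound 3 `O=C(NO)[C@H]1CCCCN1S(=O)(=O)N1CC=C(c2cccc(-c3ccccc3)c2)CC1` gives 7600 nM. Compound 2 therefore has the lowest of the three numbers and is the strongest inhibitor among them: compound 1 sits a clear way above it, and compound 3 lies much further off, with both gaps beyond the usual scatter of repeat measurements.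

Compound 4 `O=C(NO)[C@H]1CCCCN1S(=O)(=O)N1CC=C(c2ccc(Oc3ccccc3)cc2)CC1` has not yet been measured in this assay. It differs from compound 2 in one place only: phenoxy in place of fluoro on an aromatic carbon. A single small atom is thus replaced by a group that brings its own aromatic ring and an extra hydrogen-bond acceptor. Within this small set, the largest molecule, compound 3, shows the weakest number, which suggests that adding bulk at the edge of the core is not rewarded here. The expected step from this change is an 8.3-fold higher number from compound 2 to compound 4 (0.92 log units; beyond the scatter), a loss well beyond the scatter. Compound 4 is therefore estimated to give 2500 nM in this assay, with a likely range from 800 nM to 8000 nM.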

Compound 4, half-maximal inhibitory concentration: 3300 nM
The estimate for compound 4 lay 1.3-fold (0.12 log units) below the measured number; the measured number falls inside the stated range.
By their numbers in this assay, from the lowest: compound 2; then compound 1; then compound 4; then compound 3.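

In this assay, replacing fluoro with phenoxy on the aromatic carbon para to a large group gives an 11-fold higher number from compound 2 to compound 4 (1.04 log units; beyond the scatter), a large loss of inhibition. Among these compounds, this is the first comparison here in which only one place changes, and it shows that this position is sensitive to what it carries: on the core of compound 2, the single fluorine atom is clearly better than the larger group with its own aromatic ring. Nothing measured here explains the loss, so the roles of the added ring and the added oxygen cannot be separated.

From the compounds shown here alone, with only these two groups compared at this position, it remains open how a smaller oxygen-linked group such as methoxy would behave. Going by these compounds, the effect of a plain phenyl ring, an amine or a carboxylic acid there also remains open.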